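Three Measured Compounds and an Expected Fourth

This account rests on a few compounds, and the source may have more. Where it says the series, first, only, none or still open, it means among the compounds named here.

Compound 1 `CNC(=O)c1cc(C(=O)N[C@H]2CC[C@H](O)CC2)n([C@@H](C)c2cccc(Cl)c2)n1`: 235 nm/s
Compound 2 `CC[C@@H](c1ccccc1)n1nc(C(=O)NC)cc1C(=O)N[C@H]1[C@@H]2C[C@@H](O)C[C@@H]21`: 120 nm/s
Compound 3 `CC[C@@H](c1ccccc1)n1nc(C(=O)NC)cc1C(=O)N[C@H]1CC[C@H](O)CC1`: 70 nm/s

In an ADME assay for permeability (a lower number here means that the compound crosses the layer more slowly, a higher number that the compound crosses the layer faster), the three measured compounds lie close together. Compound 3 and compound 1 differ in one place, (1-(3-chlorophenyl)ethyl in place of 1-phenylpropyl on an aromatic nitrogen), and this change gives a 3.4-fold higher number from compound 3 to compound 1 (0.53 log units; beyond the scatter). Compound 2 and compound 3 differ in their cores, (a group of 7 heavy atoms (6 carbon, 1 oxygen; one three-membered non-aromatic ring of carbon only, one five-membered non-aromatic ring of carbon only) in place of a group of 7 heavy atoms (6 carbon, 1 oxygen; one six-membered non-aromatic ring of carbon only), on an amide-type nitrogen), with a 1.7-fold lower number from compound 2 to compound 3 (0.23 log units; within the scatter). Compound 4 `CNC(=O)c1cc(C(=O)N[C@H]2[C@@H]3C[C@@H](O)C[C@@H]32)n([C@@H](C)c2cccc(Cl)c2)n1` has not yet been measured in this assay. It differs from compound 2 by 1-(3-chlorophenyl)ethyl in place of 1-phenylpropyl on an aromatic nitrogen, the same change, made at the same place, as that seen between compound 3 and compound 1. Resting on a 3.4-fold higher number from compound 3 to compound 1 (0.53 log units; beyond the scatter), compound 4 is expected to show a step of a 2.8-fold higher number from compound 2 to compound 4 (0.44 log units; beyond the scatter). In this assay compound 4 is therefore estimated at 330 nm/s, with a likely range from 180 nm/s to 600 nm/s.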

Compound 4, apparent permeability: 197 nm/s
Compound 4: the middle estimate sits 1.7-fold (0.22 log units) above what was measured; measured number inside the range.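

In this assay, 1-(3-chlorophenyl)ethyl in place of 1-phenylpropyl gives a 1.6-fold higher number from compound 2 to compound 4 (0.22 log units; within the scatter), and this step cannot be told apart from the one seen on the other core: the same change on two cores in this assay, a 3.4-fold higher number (0.53 log units; beyond the scatter) from compound 3 to compound 1 and a 1.6-fold higher number (0.22 log units; within the scatter) from compound 2 to compound 4, 2.0-fold (0.31 log units) apart, within the scatter of two such steps. The change on the amide-type nitrogen gives a 1.2-fold lower number from compound 1 to compound 4 (0.08 log units; within the scatter), and it also agrees with its earlier counterpart: the same change on two cores in this assay, a 1.7-fold lower number (0.23 log units; within the scatter) from compound 2 to compound 3 and a 1.2-fold higher number (0.08 log units; within the scatter) from compound 4 to compound 1, 2.0-fold (0.31 log units) apart, within the scatter of two such steps. The two cores therefore show no measurable disagreement, but the new step lies within the scatter on its own, and two pairs do not show that the change would carry to any further core.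

Going by these compounds, in both pairs the chlorine and the change of chain enter together, so the share of each stays open. A 1-phenylethyl group on the aromatic nitrogen would be needed to separate them.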